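The compounds below may be only part of what the source reports. "The series", "measured", "known", "first", "only" and "open" are said of these compounds alone.

In an in vitro functional assay on 1321-N1 cells for agonist activity at P2Y purinoceptor 4 (Homo sapiens), read by scintillation proximity assay and inositol phosphate accumulation (on this read-out lower numbers stand for an effect already at smaller amounts and higher numbers for an effect only at larger amounts of compound), compound 1 `O=c1[nH]c(=S)ccn1[C@@H]1O[C@H](COP(=O)(O)O)[C@@H](O)[C@H]1O` reaches only the assay limit, > 100000 nM. Compound 2 `CNc1nc(=O)ccn1[C@@H]1O[C@H](COP(=O)(O)O)[C@@H](O)[C@H]1O` likewise stops at the limit, > 100000 nM. Compound 3 `CNc1nc(=O)ccn1[C@@H]1O[C@H](COP(=O)(O)OP(=O)(O)O)[C@@H](O)[C@H]1O` gives a limit as well, >= 100000 nM.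

Compound 2 therefore stands at a limit rather than a number, as do the other two values, shown by the limit of > 100000 nM in this assay, at which 2 of the 3 values shown sit, and (the limit of >= 100000 nM in this assay, at which 1 of the 3 values shown sits). Among the compounds with values here, the one measured step, a step that the two limits leave unreadable from compound 2 to compound 3, cannot be read because both ends are limits. Compound 4 `CCCSc1nc(=O)ccn1[C@@H]1O[C@H](COP(=O)(O)O)[C@@H](O)[C@H]1O` differs from compound 2 in that (propylsulfanyl in place of methylamino on an aromatic carbon). Within the data shown here, no measured step gives a readable size, so no shift beyond the scatter is expected in this assay. Compound 4 is estimated at 100000 nM, with a range from 30000 nM to 300000 nM, so that the expected step of a number no higher from compound 2 to compound 4 (the limit leaves the size open) is none beyond the scatter.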

Compound 4, half-maximal effective concentration: > 100000 nM
Compound 4 gave a limit, no number; the forecaster's own chance of this, stated with the estimate: 85%; the middle value sits exactly at the limit.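

Compound 2 and compound 4 both stop at a limit in this assay, so the step between them cannot be read. The compounds shown leave open whether propylsulfanyl and methylamino differ at all in this read-out.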